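The compounds below may be only part of what the source reports. "The series", "measured", "known", "first", "only" and "open" are said of these compounds alone.

Testing a compound against human cells shows how much of it the cells tolerate. In an ADME assay on A549 cells (Homo sapiens) for cytotoxicity, read by resazurin assay, with a stated time of 48 h (on this read-out lower numbers stand for higher toxicity in this test and higher numbers for lower toxicity in this test), compound 1 `CC(=O)Nc1ccc(NC(=O)c2cc(Cl)ccc2O)c(Cl)c1` has no numerical result, and its entry reads "not determined" (no result reported). Compound 2 `O=C(Nc1ccc(NCc2ccc(O)cc2)cc1Cl)c1cc(Cl)ccc1O` gives 116000 nM. Among the measured compounds shown here, this is the only number available, so compound 2 cannot yet be ranked against anything else, and no measured step shows how a structural change moves this value.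

The next compound to be tested is compound 3 `O=C(Nc1ccc(NCc2cnccc2Cl)cc1Cl)c1cc(Cl)ccc1O`, which differs from compound 2 in one place: 4-chloropyridin-3-yl in place of 4-hydroxyphenyl on a saturated chain carbon bound to a nitrogen on an aromatic ring. In words, 4-chloropyridin-3-yl stands in place of 4-hydroxyphenyl on a saturated chain carbon bound to a nitrogen on an aromatic ring.

The only anchor for a prediction in this assay is compound 2 at 116000 nM, so any forecast must stay cautious and its range wide. The expected change is modest, pointing towards a lower number and so somewhat higher toxicity in this test: a 1.9-fold lower number from compound 2 to compound 3 (0.29 log units; within the scatter). For compound 3 the estimated value is 60000 nM, with an expected range of 15000 nM to 200000 nM.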

Compound 3, half-maximal cytotoxic concentration: 126000 nM
For compound 3 the middle estimate is 2.1-fold (0.32 log units) below the measured one, and the stated range covers the measured number.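

In this assay, this change gives a 1.1-fold higher number from compound 2 to compound 3 (0.04 log units; within the scatter), so the two compounds cannot be told apart on this read-out. Among the compounds shown here, this is the first measured step at this place, on a saturated chain carbon bound to a nitrogen on an aromatic ring, and it shows that swapping 4-hydroxyphenyl for 4-chloropyridin-3-yl keeps the number within the scatter, even though the hydrogen-bond donor leaves and a ring nitrogen and a chlorine enter. No measurement shown here offers an explanation for this result, so it stands only as an observation about this pair.

One step on one pair cannot show whether this position tolerates changes in general, or whether the hydroxyl, the ring nitrogen or the chlorine matters on its own in this test. Going by these compounds, it also remains open whether a carboxylic acid or an amine on this ring, or a longer chain between the ring and the nitrogen, would move the number beyond the scatter.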